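Removing the ring fluorine from compound 1: notes on compound 4

A few compounds are considered here, and "the series" means these few. Any claim that something is new, unique, unknown or untested is made for them only; others in the source may bear on it.

Measured compounds:
compound 1 `O=S(=O)(NCCCNc1nccc(-c2c(-c3cccc(F)c3)nc3sccn23)n1)c1cccc(F)c1` – 13700 nM
compound 2 `O=C(NCCNc1nccc(-c2c(-c3cccc(F)c3)nc3sccn23)n1)c1ccc(Cl)cc1` – 2570 nM
compound 3 `O=S(=O)(NCCNc1nccc(-c2c(-c3cccc(F)c3)nc3sccn23)n1)c1cccc(F)c1` – 14900 nM

In a functional assay on A-375 cells (Homo sapiens) for cytotoxicity, read by MTT assay (on this read-out higher numbers stand for weaker inhibition and lower numbers for stronger inhibition), compound 1 gives 13700 nM, the second highest of the three numbers. Its nearest neighbour is compound 3, whose value of 14900 nM sits within the scatter (a 1.1-fold higher number from compound 1 to compound 3 (0.04 log units; within the scatter)); the furthest is compound 2 at 2570 nM (a 5.3-fold lower number from compound 1 to compound 2 (0.73 log units; beyond the scatter)). The step of a 5.8-fold higher number from compound 2 to compound 3 (0.76 log units; beyond the scatter) is of similar size and likewise beyond the scatter.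

Compound 4 `O=S(=O)(NCCCNc1nccc(-c2c(-c3cccc(F)c3)nc3sccn23)n1)c1ccccc1` differs from compound 1 only by hydrogen in place of fluoro on an aromatic carbon on the sulfonyl-bearing ring; the chain and the rest of the shared core are unchanged. Among the measured compounds shown here, none of the measured steps touches that ring substituent: the steps among compounds 1, 2 and 3 concern the chain length and the sulfonyl-versus-carbonyl exchange, and the sulfonyl pair is retained here. No step beyond the scatter is therefore expected in this assay for this change.

Compound 4 is accordingly estimated at 13000 nM (range 5500 nM to 32000 nM), the expected step from compound 1 being a 1.1-fold lower number from compound 1 to compound 4 (0.02 log units; within the scatter).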

Compound 4, half-maximal inhibitory concentration: 6600 nM
Compound 4: the middle estimate sits 2.0-fold (0.29 log units) above what was measured; the range from low to high includes it.
By their numbers in this assay, from the lowest: compound 2; then compound 4; then compounds 1 and 3 (each within the scatter of the next).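

In this assay, among the compounds shown here, the ring substituent on the sulfonyl side is not silent: the change gives a 2.1-fold lower number from compound 1 to compound 4 (0.32 log units; beyond the scatter) and is the first step at this place. Set against compound 3, the same ring gives a 2.3-fold lower number from compound 3 to compound 4 (0.35 log units; beyond the scatter) in a step that also differs in the chain, while compounds 1 and 3 themselves sit within the scatter of each other. The phenylsulfonyl compound still does not reach the (4-chlorophenyl)carbonyl compound, with a 2.6-fold higher number from compound 2 to compound 4 (0.41 log units; beyond the scatter) in a step that changes both the chain and the capping group.

No evidence at hand accounts for the step. Still open, from the compounds shown here alone, is whether chloro or methoxy in the same place, meta to a large group, would read like fluoro or like hydrogen, and whether removing fluoro gives a similar step on the shorter chain of compound 3.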